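Furan to Thiophene Swap on a Porcupine Inhibitor Series

The source may hold more compounds than are shown below. What is called first, only, known or untested is meant among the compounds shown, and "the series" means these compounds.

Measured so far:
- compound 1, `O=C(CSc1nc2c(c(=O)n1-c1ccccc1)SCC2)Nc1ccc(-c2ccoc2)cn1`: 1.5 nM
- compound 2, `O=C(CSc1nc2c(c(=O)n1-c1ccccc1)SCC2)Nc1ncc(-c2ccoc2)cn1`: 1.5 nM

Compound 1 was tested in an assay on L cells for inhibition of Protein-serine O-palmitoleoyltransferase porcupine (Mus musculus), read by reporter gene assay, with a stated time of 24 h; on this read-out lower numbers stand for an effect already at smaller amounts and higher numbers for an effect only at larger amounts of compound. In this assay compound 1 gives 1.5 nM. Compound 2 gives 1.5 nM in this assay, so the two compounds stand level at the digits shown; the gap between them is within the scatter, and neither can be called the stronger one.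

Compound 3, `O=C(CSc1nc2c(c(=O)n1-c1ccccc1)SCC2)Nc1ccc(-c2ccsc2)cn1`, has not yet been measured in this assay. It differs from compound 1 in one place: thiophen-3-yl in place of furan-3-yl on an aromatic carbon. The change puts thiophen-3-yl where furan-3-yl stood, on an aromatic carbon of a six-membered aromatic ring with 1 nitrogen, para to a large group.

For the measured compounds named here, no step between measured compounds is available to set a size for this kind of exchange. The two measured compounds give no sign that small changes in this part of the molecule move the read-out, so the step expected from compound 1 to compound 3 is a 1.3-fold higher number from compound 1 to compound 3 (0.12 log units; within the scatter), none beyond the scatter. Compound 3 is therefore estimated at 2 nM, with a range from 0.7 nM to 6 nM.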

Compound 3, half-maximal effective concentration: 2 nM
Beside the measured number, compound 3's estimate shows no gap at the digits printed, within the range that was stated.
By their numbers in this assay, from the lowest: compounds 1, 2 and 3 (each within the scatter of the next).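

For the compounds shown here, this is the first step that can be read at this position: in this assay the exchange of furan-3-yl for thiophen-3-yl gives a 1.3-fold higher number from compound 1 to compound 3 (0.12 log units; within the scatter) with both rings sitting on the same aromatic carbon. The entering and leaving groups have the same count of heavy atoms and differ in one ring atom, sulfur for oxygen, so that single exchange within a five-membered aromatic ring leaves no readable change here. No measurement at hand bears on the reason for this result.

Going by these compounds, it remains open whether the position would tolerate something other than a five-membered aromatic ring, such as an amine, a carboxylic acid or a longer chain. On these data alone, it is also open whether thiophen-3-yl would read the same on the ring carried by compound 2.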